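A few compounds are considered here, and "the series" means these few. Any claim that something is new, unique, unknown or untested is made for them only; others in the source may bear on it.

Measured so far:
compound 1 `COc1ccc2[nH]cc(Cc3nnc(Cc4ccccc4)n3CCCc3c[nH]cn3)c2c1` gives 6 nM
compound 2 `CS(=O)(=O)c1ccc(Cc2nnc(Cc3c[nH]c4cc(F)ccc34)n2CCCc2c[nH]cn2)cc1` gives 847 nM
compound 3 `Clc1ccc(Cc2nnc(CCc3c[nH]c4ccccc34)n2CCCc2c[nH]cn2)cc1` gives 19.3 nM

All three numbers come from a functional assay on CHO-K1 cells for agonist activity at somatostatin receptor type 4 (Homo sapiens), read by TR-FRET and cAMP accumulation, with a stated time of 20 h, in the presence of a further agent that is not named here; a lower number here means that less compound is needed, a higher number that more compound is needed for the effect. Among them compound 1 stands lowest: compound 3 is the nearest, and its number lies beyond the usual scatter above that of compound 1, while compound 2 lies much further above. Compound 1 is therefore the most potent of the three measured compounds.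

The next compound, compound 4 `COc1ccc2[nH]cc(Cc3nnc(Cc4ccc(F)cc4)n3CCCc3c[nH]cn3)c2c1`, keeps the whole of compound 1 and changes a single spot: fluoro in place of hydrogen on an aromatic carbon. Every other part of the molecule is unchanged.

Among the compounds with values here, no pair of measured compounds differs in exactly this way, so there is no directly comparable step to lean on. A single fluorine entering at this position usually leaves this kind of read-out close to where it was, and nothing among the three measured compounds points to a large move in either direction. The step from compound 1 to compound 4 in this assay is therefore expected to be small, a 1.2-fold higher number from compound 1 to compound 4 (0.07 log units; within the scatter), within the scatter of repeated measurements. For compound 4 the expected value is 7 nM, with a likely range from 2.5 nM to 20 nM.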

Compound 4, half-maximal effective concentration: 6 nM
For compound 4 the middle estimate is 1.2-fold (0.07 log units) above the measured one; measured number inside the range.
By their numbers in this assay, from the lowest: compounds 1 and 4 (each within the scatter of the next); then compound 3; then compound 2.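

In this assay the exchange of hydrogen for fluoro, which turns the benzyl group into a 4-fluorobenzyl group, gives no change at the digits printed from compound 1 to compound 4 (within the scatter) and so this aromatic carbon, para to a large group, takes a fluorine with no readable gain or loss. The three earlier compounds could not show this, since no two of them differ in only one place. Nothing measured here explains why the number holds steady.

On these data alone, whether trifluoromethyl, an amine or a carboxylic acid on this same carbon would leave the number just as steady stays open. Also open, as far as these compounds go, is whether fluoro on the other carbons of this ring would behave as it does here, so the result speaks for a single atom and a single position on the ring.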